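The compounds below may be only part of what the source reports. "The series", "measured", "known", "first", "only" and "open" are said of these compounds alone.

In an in vitro functional assay on 1321-N1 cells for agonist activity at P2Y purinoceptor 6 (Homo sapiens) (on this read-out lower numbers stand for an effect already at smaller amounts and higher numbers for an effect only at larger amounts of compound), three compounds built on one shared core have been measured so far. Compound 1 `O=c1cc(I)n([C@@H]2O[C@H](COP(=O)(O)OP(=O)(O)O)[C@@H](O)[C@H]2O)c(=O)[nH]1` gives 15 nM. Compound 3 `Cn1c(=O)ccn([C@@H]2O[C@H](COP(=O)(O)OP(=O)(O)O)[C@@H](O)[C@H]2O)c1=O` gives 3300 nM. Compound 2 `C=CCSc1ccn([C@@H]2O[C@H](COP(=O)(O)OP(=O)(O)O)[C@@H](O)[C@H]2O)c(=O)n1` gives 560 nM, which is the second highest of the three numbers: its nearest neighbour is compound 3, whose number is higher by a gap beyond the usual scatter, and its furthest is compound 1, whose number is lower by a far wider gap, also beyond the scatter.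

Compound 4 `NC(=O)CSc1ccn([C@@H]2O[C@H](COP(=O)(O)OP(=O)(O)O)[C@@H](O)[C@H]2O)c(=O)n1` has not yet been measured. It differs from compound 2 in one place: carbamoyl in place of vinyl on a saturated chain carbon bound to a sulfur. Among the compounds with values here, no two measured compounds differ from each other in a single place, so there is no directly comparable step to lean on; the expectation rests on the spread of the three numbers and on the nature of the change alone. The step of a 2.1-fold higher number from compound 2 to compound 4 (0.33 log units; beyond the scatter) is expected to run towards a higher number, of moderate size, though it may turn out to lie within the scatter. Compound 4 is accordingly estimated at 1200 nM, with a range from 250 nM to 5000 nM.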

Compound 4, half-maximal effective concentration: 18000 nM
The estimate for compound 4 lay 15-fold (1.18 log units) below the measured number; the measured number lies above the stated range.
By their numbers in this assay, from the lowest: compound 1; then compound 2; then compound 3; then compound 4.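

Exchanging vinyl for carbamoyl on a saturated chain carbon bound to a sulfur gives, in this assay, a 32-fold higher number from compound 2 to compound 4 (1.51 log units; beyond the scatter), so this position is far from indifferent to what ends the chain. This is the first change in a single place among the compounds shown, and it shows that replacing allyl with carbamoylmethyl on the sulfur costs a large amount of agonist effect at a given concentration. No measurement here explains the size of this step.

Carbamoyl differs from vinyl in its atoms and in bringing a hydrogen-bond donor and acceptor, and one step cannot separate these differences. From the compounds shown here alone, how a carboxylic acid, an amine or a saturated propyl chain on the same sulfur would compare remains open.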